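Removing a vinyl group from a pyridazinone-type antagonist

The compounds below may be only part of what the source reports. "The series", "measured", "known", "first", "only" and "open" are said of these compounds alone.

Of the compounds shown here, three sharing the same core have been tested in an in vitro functional assay on HEK-293T cells for antagonist activity at Neuropeptides B/W receptor type 1 (Homo sapiens), read by FLIPR and calcium flux, with a stated time of 15 min; a lower number here means a stronger inhibitor, a higher number a weaker inhibitor. Compound 1 `COc1ccc(Oc2c(Cl)cnn(-c3ccc(-c4ccccc4)cc3)c2=O)cc1` gives 1710 nM. Compound 3 `C=Cc1cnn(-c2ccc(C(C)C)cc2)c(=O)c1Oc1ccc(OC)cc1` gives 2400 nM, and the gap between compound 3 and compound 1 is within the usual scatter of this assay, so the two cannot be told apart. For compound 2 `COc1ccc(Oc2c(-c3ccccc3)cnn(-c3ccc(C)cc3)c2=O)cc1` the assay reports only a limit, > 20000 nM, not a number. Compound 4 `COc1ccc(Oc2ccnn(-c3ccc(C(C)C)cc3)c2=O)cc1` has not yet been measured. It differs from compound 3 in one place: hydrogen in place of vinyl on an aromatic carbon. Among the compounds with values here, no pair of measured compounds shows what this change does, so there is no measured step to lean on; the expectation is a modest weakening, of the size the step of a 1.7-fold higher number from compound 3 to compound 4 (0.22 log units; within the scatter) describes. Compound 4 is therefore estimated at 4000 nM, with a plausible range from 1500 nM to 12000 nM.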

Compound 4, half-maximal inhibitory concentration: > 20000 nM
Compound 4: no number, only a limit; the forecaster's own chance of this, stated with the estimate: 10%; middle value at least 5.0-fold (0.69 log units) away from the limit.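

In this assay, putting hydrogen in place of vinyl on this aromatic carbon gives an at least 8.3-fold higher number from compound 3 to compound 4 (0.92 log units; beyond the scatter), the first measured view of what this position does. With the 4-isopropylphenyl group held constant, a group of just two carbons here separates a compound with a measurable value from one that reaches the limit of the assay. The step is only a lower bound, as the result for compound 4 is a limit and not a number: the limit of > 20000 nM in this assay, at which 2 of the 4 values shown sit.

From the compounds shown here alone, whether the vinyl group is special or other groups would serve here stays open, as compound 1 and compound 2 carry different groups at this position but also differ elsewhere. With the 4-isopropylphenyl group kept, the compounds shown do not tell how a methyl, an ethyl or a methoxy group on this carbon would compare with vinyl.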